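Solubility notes: an amino substituent on the pyridyl amide

A few compounds are considered here, and "the series" means these few. Any claim that something is new, unique, unknown or untested is made for them only; others in the source may bear on it.

Measured so far in a physicochemical assay for solubility, at pH 7.4; a higher number here means a more soluble compound, a lower number a less soluble compound:
compound 1, `Cc1cc(C)c(-c2c[nH]nc2C)cc1NC(=O)c1ccc(OCc2ccccn2)cc1`: 33000 nM
compound 2, `Cc1cc(C)c(-c2ccccn2)cc1NC(=O)c1ccc(OCc2ccccn2)cc1`: < 1000 nM

Compound 1 `Cc1cc(C)c(-c2c[nH]nc2C)cc1NC(=O)c1ccc(OCc2ccccn2)cc1` gives 33000 nM in this assay. For compound 2 `Cc1cc(C)c(-c2ccccn2)cc1NC(=O)c1ccc(OCc2ccccn2)cc1` the assay reports only a limit, < 1000 nM, not a number. Within the data shown here, the single measured step, an at least 33-fold lower number from compound 1 to compound 2 (1.51 log units; beyond the scatter), is large, and it is open-ended because the limit of < 1000 nM in this assay, at which 1 of the 2 values shown sits, is where compound 2 sits. Compound 2 therefore stands at the less soluble end of the two values shown, with its true value unknown below that limit.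

Compound 3 `Cc1cc(C)c(-c2cccc(N)n2)cc1NC(=O)c1ccc(OCc2ccccn2)cc1` is compound 2 with amino in place of hydrogen on an aromatic carbon. Among the measured compounds shown here, no measured step adds a small group to the pyridin-2-yl; the only step on hand swaps the whole aromatic substituent, so it gives no size to carry over to this change. The expectation for compound 3 rests only on the limit for compound 2 and on the usual scatter. Compound 3 is estimated at 1200 nM in this assay, within 250 nM to 6000 nM. That estimate means an expected at least 1.2-fold higher number from compound 2 to compound 3 (0.07 log units; that floor lies within the scatter), measured against a limit rather than a number.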

Compound 3, solubility: 2000 nM
The estimate for compound 3 lay 1.7-fold (0.22 log units) below the measured number; measured number inside the range.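

Amino on an aromatic carbon next to the ring nitrogen of the pyridin-2-yl is a change of one small group, which the earlier pair, with its swap of the whole aromatic substituent, could not show; in this assay it gives an at least 2.0-fold higher number from compound 2 to compound 3 (0.30 log units; that floor lies within the scatter) as the step. That floor lies within the scatter, and the true size of the step cannot be read because compound 2 is known only through a limit: the limit of < 1000 nM in this assay, at which 1 of the 3 values shown sits. The 6-aminopyridin-2-yl also stays well short of the 3-methyl-1H-pyrazol-4-yl, with a 17-fold lower number from compound 1 to compound 3 (1.22 log units; beyond the scatter) as the step, so amino on this carbon does not close the large gap between the two aromatic substituents.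

From the compounds shown here alone, it remains open whether a methylamino, a dimethylamino, a hydroxyl or a methoxy on the same carbon would read like amino, and whether amino on another carbon of the pyridin-2-yl would give a similar number. Also open is whether amino on its own accounts for the reading, since the compounds shown hold only this one substituent on the pyridin-2-yl and give no comparison with any other group there.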